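Mirror images under test: compound 2 and compound 3

This account rests on a few compounds, and the source may have more. Where it says the series, first, only, none or still open, it means among the compounds named here.

- compound 1 `O=C(CNC1CC1c1cc(F)cc(F)c1OCc1cccnc1F)N1CCC2(CCNC2)CC1`: 56%
- compound 2 `O=C(CN[C@H]1C[C@@H]1c1cc(F)cc(F)c1OCc1cccnc1F)N1CCC2(CCNC2)CC1`: 62%

In an ADME assay on microsomes from liver (Rattus norvegicus) for metabolic stability, read by mass spectrometry, using NADPH, with a stated time of 60 min (a lower number here means that less of the compound is left, a higher number that more of the compound is left), compound 2 gives 62%, level with compound 1 at 56%. The measured step is a number 6 percentage points higher from compound 1 to compound 2 (within the scatter), so the numbers do not separate the two. What distinguishes them is the fact that one of compounds 1 and 2 is drawn with a defined configuration and the other without, at the place where they differ.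

Compound 3 `O=C(CN[C@@H]1C[C@H]1c1cc(F)cc(F)c1OCc1cccnc1F)N1CCC2(CCNC2)CC1` is the mirror image of compound 2 : the two compounds have the same atoms and bonds and differ only in configuration as drawn: 2 of 2 stereo elements differ (all stereocentres are inverted: mirror images); a stereocentre at a saturated ring carbon is drawn S in compound 2 and R in compound 3; a stereocentre at a saturated ring carbon is drawn R in compound 2 and S in compound 3. Among the compounds with values here, no group leaves and none enters, so the only change is the drawn configuration.

Within the data shown here, only that one small step bears on this change. Compound 1 is drawn without configuration, yet the data do not say which forms it contains. If it holds both mirror images, compound 1 at 56% gives no sign of a large gap between them. A single step is thin evidence, so the range must stay wide. No step beyond the scatter is expected in this assay, and the estimated step is a number 6 percentage points lower from compound 2 to compound 3 (within the scatter). For compound 3 the expected value is 56%, with an estimated range from 42% to 70%.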

Compound 3, percent of the compound remaining: 55%
The estimate for compound 3 lay 1 percentage points above the measured number; low and high end bracket the measured number.
By their numbers in this assay, from the lowest: compounds 3, 1 and 2 (each within the scatter of the next).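

Inverting both stereocentres gives a number 7 percentage points lower from compound 2 to compound 3 (within the scatter), the first direct test of this change between two forms with a fully drawn configuration. In this assay, the drawn configuration at these two saturated ring carbons therefore makes no difference that can be told apart from the scatter, and this comparison is a clean one with nothing else to confuse it: the fact that compounds 2 and 3 differ only in the configuration as drawn The form drawn without configuration also stays level with the second defined form, with a number 1 percentage points lower from compound 1 to compound 3 (within the scatter), so compound 1, compound 2 and compound 3 cannot be separated by the amount left after the stated time.

The compounds shown leave open whether the two mirror images also stay level in any other kind of measurement, as only this one read-out is given here, and a true gap smaller than the scatter would not show up in it. They also leave open whether the mirror images would remain this close if a fluorine on the shared core gave way to a chlorine or a nitrile.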